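The source may hold more compounds than are shown below. What is called first, only, known or untested is meant among the compounds shown, and "the series" means these compounds.

In an assay on isolated protein for inhibition of aldehyde dehydrogenase 1A1 (Homo sapiens), read by spectrophotometry, tested at 10 uM (on this read-out higher numbers stand for more inhibition at the one concentration tested (going by the name of the read-out) and lower numbers for less inhibition), compound 1 `O=C(C1CC1)N1CCN(Cc2nc3ccccc3n2Cc2ccc(Cl)cc2)CC1` gives 56.6%, while compound 2 `CC(C)Cn1c(CN2CCN(C(=O)C3CC3)CC2)nc2ccccc21` gives 13.1%, the lower of the two numbers. The step of a number 43.5 percentage points lower from compound 1 to compound 2 (beyond the scatter) is the only one measured and bears directly on the change at hand, since compound 3 `O=C(C1CC1)N1CCN(Cc2nc3ccccc3n2Cc2cccc(F)c2)CC1` differs from compound 2 by 3-fluorophenyl in place of isopropyl on a saturated chain carbon bound to an aromatic nitrogen, an aryl group entering where the earlier step removed one. Compound 3 is therefore expected to climb back toward compound 1 in this assay, and its estimated step of a number 31.9 percentage points higher from compound 2 to compound 3 (beyond the scatter) would be large. The estimate for compound 3 is 45%, with a range from 20% to 70%.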

Compound 3, a percentage reported as inhibition, at one concentration (the size of the read-out at that concentration, not a potency): 27.2%
For compound 3 the middle estimate is 17.8 percentage points above the measured one, and the stated range covers the measured number.
By their numbers in this assay, from the lowest: compound 2; then compound 3; then compound 1.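

In this assay, the step of a number 14.1 percentage points higher from compound 2 to compound 3 (beyond the scatter) shows that a 3-fluorophenyl group on a saturated chain carbon bound to an aromatic nitrogen gives more inhibition than isopropyl. The step of a number 29.4 percentage points lower from compound 1 to compound 3 (beyond the scatter) shows that this recovers only part of the level reached with 4-chlorophenyl, so the two aryl groups are not interchangeable at this place. Nothing measured here accounts for that gap. Open, from the compounds shown here alone, is whether the identity of the halogen or its place on the ring sets the gap between 3-fluorophenyl and 4-chlorophenyl, and how an unsubstituted phenyl or a 3-chlorophenyl would read here.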